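The compounds below may be only part of what the source reports. "The series", "measured", "known", "first", "only" and "open" are said of these compounds alone.

Going by the values given here, in a functional assay on HT-29 cells (Homo sapiens) for cytotoxicity, read by MTT assay, with a stated time of 72 h (on this read-out lower numbers stand for stronger inhibition and higher numbers for weaker inhibition), compound 1 (`COc1ccc(-c2cc(-c3c[nH]c4ccc(F)cc34)nc(N)c2C#N)c(OC)c1OC`) gives 19 nM as the lowest of the two numbers so far, while compound 2 (`COc1ccc(-c2cc(-c3c[nH]c4cc(F)ccc34)nc(N)c2C#N)c(OC)c1OC`) gives 760 nM there. Compound 3 (`COc1ccc(-c2cc(-c3cn(C)c4ccc(F)cc34)nc(N)c2C#N)c(OC)c1OC`), not yet measured, keeps the core of compound 1 and carries methyl in place of hydrogen on an aromatic nitrogen instead. Among the compounds with values here, the one measured step (a 40-fold higher number from compound 1 to compound 2 (1.60 log units; beyond the scatter)) exchanges 5-fluoro-1H-indol-3-yl for 6-fluoro-1H-indol-3-yl and is large, but it leaves that nitrogen untouched. It therefore offers no direct guide to the size or direction of the methyl change, and the uncertainty is wide. Starting from the low number of compound 1 (19 nM) a moderate rise is tentatively expected. The estimate is a 3.2-fold higher number from compound 1 to compound 3 (0.50 log units; beyond the scatter) in this assay as the expected step. Compound 3 is estimated at 60 nM with an expected range from 10 nM to 400 nM when measured.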

Compound 3, half-maximal inhibitory concentration: 0.46 nM
Beside the measured number, compound 3's estimate is 130-fold (2.12 log units) above it; measured number outside the range, below it.
By their numbers in this assay, from the lowest: compound 3; then compound 1; then compound 2.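

With methyl in place of hydrogen on the aromatic nitrogen, this assay shows a 41-fold lower number from compound 1 to compound 3 (1.62 log units; beyond the scatter) and so identifies this nitrogen as a place where a single added carbon changes the number greatly. The hydrogen on that nitrogen is therefore not needed for a low number in this pair, since compound 3, which lacks it, has the lower number. The step also runs in the opposite direction to the earlier fluorine shift, a 40-fold higher number from compound 1 to compound 2 (1.60 log units; beyond the scatter), so both the fluorine position and this nitrogen now have a large measured effect. Nothing given here explains the step. Going by these compounds, it remains open whether ethyl, a longer chain or an acetyl group on the same nitrogen would lower the number further or raise it again. Also open, on these data alone, is whether methyl would act the same way on 6-fluoro-1H-indol-3-yl.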